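This account rests on a few compounds, and the source may have more. Where it says the series, first, only, none or still open, it means among the compounds named here.

Measured so far in a functional assay on CHO-RD-HGA16 cells for agonist activity at Orexin receptor type 2 (Homo sapiens), read by fluorescence and calcium flux, with a stated time of 30 min; a lower number here means that less compound is needed, a higher number that more compound is needed for the effect:
- compound 1 `COc1ccc(-c2cccc(C(=O)N(C)C)c2)cc1S(=O)(=O)Nc1cccc(NCC(C)NC(=O)c2cccc(C)c2)c1`: 376 nM
- compound 2 `COc1ccc(-c2cccc(C(=O)NCCN(C)C)c2)cc1S(=O)(=O)Nc1cccc(NCCNC(=O)c2cccc(C)c2)c1`: 1630 nM

Compound 2 stands at the higher of the two numbers; the gap from compound 1 to compound 2 is beyond the scatter, so compound 2 needs more compound for the effect than compound 1 does. The two differ in more than one place, so no single step can be read from them.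

Compound 3 `COc1ccc(-c2cccc(C(=O)N(C)Cc3cccnc3)c2)cc1S(=O)(=O)Nc1cccc(NCCNC(=O)c2cccc(C)c2)c1` is not yet measured. It departs from compound 2 by one change: methyl((pyridin-3-yl)methyl)amino in place of (2-(dimethylamino)ethyl)amino on a carbonyl carbon. For the measured compounds named here, no measured pair shows this change, so the expected size rests only on the spread between compound 1 and compound 2. Compound 1 carries a tertiary amide at the same carbonyl and gives the lower number, so a modest move toward lower numbers is expected for compound 3, of the order of a 2.3-fold lower number from compound 2 to compound 3 (0.37 log units; beyond the scatter), though a result within the scatter of compound 2 would not surprise. Compound 3 is estimated at 700 nM, between 250 nM and 2000 nM.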

Compound 3, half-maximal effective concentration: 134 nM
Beside the measured number, compound 3's estimate is 5.2-fold (0.72 log units) above it; the measured number lies below the stated range.
By their numbers in this assay, from the lowest: compound 3; then compound 1; then compound 2.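

For the compounds shown here, on a carbonyl carbon, methyl((pyridin-3-yl)methyl)amino in place of (2-(dimethylamino)ethyl)amino gives a 12-fold lower number from compound 2 to compound 3 (1.09 log units; beyond the scatter) in this assay, the first single-place reading and a large one, so the group at this place strongly affects the number. The group that enters has a six-membered aromatic ring with 1 hetero atom and 0 hydrogen-bond donors, while the group that leaves has no ring and 1 hydrogen-bond donor. No measurement here assigns the step to any one of these differences.

Still open, as far as these compounds go, is whether the pyridine ring nitrogen matters, which a benzyl group or a pyridin-4-ylmethyl group at the same place would test. Also open, from the compounds shown here alone, is the part played by the methyl on the amide nitrogen, which the plain (pyridin-3-yl)methylamino group would address.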